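This account rests on a few compounds, and the source may have more. Where it says the series, first, only, none or still open, it means among the compounds named here.

Among the compounds with values here, compound 3 `COc1cccc(C(=O)c2sc3nc(-c4cccs4)ccc3c2N)c1` gives 0.03 ug/mL in a functional assay on WI-38 VA13 cells (Homo sapiens) for cytotoxicity (on this read-out higher numbers stand for an effect only at larger amounts of compound and lower numbers for an effect already at smaller amounts), the lowest of the three numbers measured so far. Its nearest companion is compound 1 `COc1ccc(OC)c(C(=O)c2sc3nc(-c4cccs4)ccc3c2N)c1`, which in this assay gives 0.079 ug/mL; the step of a 2.6-fold lower number from compound 1 to compound 3 (0.42 log units; beyond the scatter) is modest. Compound 2 `CC(C)(C)C(=O)c1sc2nc(-c3cccs3)ccc2c1N` gives 0.57 ug/mL in this assay, and the step of a 19-fold lower number from compound 2 to compound 3 (1.28 log units; beyond the scatter) is large. Compound 4 `Nc1c(C(=O)c2cccc([N+](=O)[O-])c2)sc2nc(-c3cccs3)ccc12` has not yet been measured. It differs from compound 3 in a single place: nitro in place of methoxy on an aromatic carbon. Within the data shown here, of the measured steps, only a 2.6-fold lower number from compound 1 to compound 3 (0.42 log units; beyond the scatter) concerns a change on that same ring, and it was modest; no measured step exchanges one such substituent for another. The large step of a 19-fold lower number from compound 2 to compound 3 (1.28 log units; beyond the scatter) replaces the whole group on the carbonyl carbon and so says little about a change within the ring. A small step is therefore expected, in either direction, quite possibly not beyond the scatter. Compound 4 is estimated at 0.05 ug/mL, with a range from 0.015 ug/mL to 0.15 ug/mL. The expected step is a 1.7-fold higher number from compound 3 to compound 4 (0.22 log units; within the scatter).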

Compound 4, half-maximal effective concentration: 0.15 ug/mL
Beside the measured number, compound 4's estimate is 3.0-fold (0.48 log units) below it; the measured number falls inside the stated range.
By their numbers in this assay, from the lowest: compound 3; then compounds 1 and 4 (each within the scatter of the next); then compound 2.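

Exchanging one substituent for another at this carbon, meta to a large group, changes the result in this assay: nitro in place of methoxy gives a 5.0-fold higher number from compound 3 to compound 4 (0.70 log units; beyond the scatter). Within the data shown here, the one earlier step on this ring, a 2.6-fold lower number from compound 1 to compound 3 (0.42 log units; beyond the scatter), removed a methoxy from a different carbon and left the methoxy at this position in place, so it could not show how this position responds to a new substituent. No measurement shown explains the rise in the number with nitro.

With only methoxy and nitro compared here, two groups cannot show whether the trend would continue with an amine, a hydroxyl group or a chlorine on the same carbon. Going by these compounds, it also remains open whether nitro would give a similar step on another carbon of this ring.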